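Swapping an aminomethylphenyl arm for an aminomethyl-branched chain

This account rests on a few compounds, and the source may have more. Where it says the series, first, only, none or still open, it means among the compounds named here.

Compound 2 `NCc1cccc(CN(C[C@H]2Cc3ccccc3CN2)[C@H]2CCCc3cccnc32)c1` shows the highest of the two numbers measured in a functional assay on cells for antagonist activity at C-X-C chemokine receptor type 4 (Homo sapiens), read by fluorescence and calcium flux, with stated times of 25 min and 90 s (on this read-out lower numbers stand for stronger inhibition and higher numbers for weaker inhibition), giving 292 nM, while compound 1 `c1ccc2c(c1)CN[C@@H](CN(CCCCNCC1CCCCC1)[C@H]1CCCc3cccnc31)C2` gives 158 nM; the step of a 1.8-fold higher number from compound 1 to compound 2 (0.27 log units; within the scatter) lies within the scatter. Compound 3 `CC(C)(CN)CCN(C[C@H]1Cc2ccccc2CN1)[C@H]1CCCc2cccnc21` differs from compound 2 by 2-(aminomethyl)-2-methylpropyl in place of 3-(aminomethyl)phenyl on a saturated chain carbon bound to an amine nitrogen. Among the compounds with values here, the only measured step touching this position, from compound 1 to compound 2, was small, so the change to compound 3 is expected to bring no step beyond the scatter, with a slight lean toward a lower number, a 1.2-fold lower number from compound 2 to compound 3 (0.09 log units; within the scatter). Compound 3 is therefore estimated at 240 nM, within 80 nM to 750 nM.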

Compound 3, half-maximal inhibitory concentration: 69 nM
Beside the measured number, compound 3's estimate is 3.5-fold (0.54 log units) above it; the whole stated range lies above it.
By their numbers in this assay, from the lowest: compound 3; then compounds 1 and 2 (each within the scatter of the next).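

In this assay, within the data shown here, 2-(aminomethyl)-2-methylpropyl gives the first step at this position that lies beyond the scatter (a 4.2-fold lower number from compound 2 to compound 3 (0.63 log units; beyond the scatter)), so this position does respond to the group placed there. The arm without a ring also compares favourably with the longer arm that carries the cyclohexylmethyl amine (a 2.3-fold lower number from compound 1 to compound 3 (0.36 log units; beyond the scatter)). Nothing available explains these steps. Still open, from the compounds shown here alone, is whether the methyl groups on the chain are needed, or whether an unbranched chain ending in an amine would serve as well. Equally open, going by these compounds, is what a carboxylic acid would do in place of the aminomethyl group.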